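A few compounds are considered here, and "the series" means these few. Any claim that something is new, unique, unknown or untested is made for them only; others in the source may bear on it.

Of the compounds shown here, two have so far been tested in an assay on CHO cells for displacement of a labelled ligand from adenosine receptor A1 (Homo sapiens); a lower number here means a stronger inhibitor, a higher number a weaker inhibitor. Compound 1 `CCNC(=O)[C@H]1O[C@@H](n2cnc3c(NNC(=O)c4ccc(Cl)cc4)ncnc32)[C@H](O)[C@@H]1O` gives only a limit, > 5000 nM, in this assay. Among the compounds with values here, compound 2 `CCNC(=O)[C@H]1O[C@@H](n2cnc3c(NNC(=O)c4ccco4)nc(Cl)nc32)[C@H](O)[C@@H]1O` is the sole compound with a number, giving 3500 nM in this assay. Compound 3 `CCNC(=O)[C@H]1O[C@@H](n2cnc3c(NNC(=O)c4cc(C)on4)nc(Cl)nc32)[C@H](O)[C@@H]1O` differs from compound 2 in a single place: 5-methyl-1,2-oxazol-3-yl in place of furan-2-yl on a carbonyl carbon. Within the data shown here, no measured pair shares this change, so no measured step guides it. The expected step is a 1.1-fold higher number from compound 2 to compound 3 (0.06 log units; within the scatter), within the scatter and, if anything, toward a weaker value. Compound 3 is therefore estimated at 4000 nM, with a range from 1500 nM to 12000 nM.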

Compound 3, inhibition constant: > 5000 nM
Compound 3 was reported as a limit (the forecaster's own chance of this, stated with the estimate: 40%); at least 1.2-fold (0.09 log units) between middle value and limit.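

On the carbonyl carbon, 5-methyl-1,2-oxazol-3-yl in place of furan-2-yl gives in this assay an at least 1.4-fold higher number from compound 2 to compound 3 (0.15 log units; that floor lies within the scatter). Within the data shown here, this is the first step read at this position, and it shows that this change does not give a stronger inhibitor. The step is a floor and not a size: the limit of > 5000 nM in this assay, at which 2 of the 3 values shown sit.

On these data alone, it remains open whether a thiophen-2-yl ring, an amine or a longer chain on this carbonyl carbon would give a lower number. Compound 1 differs from compound 2 in more than one place, so it cannot settle this.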